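A few compounds are considered here, and "the series" means these few. Any claim that something is new, unique, unknown or untested is made for them only; others in the source may bear on it.

In a functional assay on A549 cells (Homo sapiens) for cytotoxicity, read by MTT assay, with a stated time of 72 h (on this read-out lower numbers stand for stronger inhibition and higher numbers for weaker inhibition), compound 2 `COc1cc2ncnc(Nc3ccc(F)c(Cl)c3)c2cc1NC(=O)N/N=C/c1ccc(O)c(Br)c1` reads 28600 nM and stands higher of the two measured, weaker than compound 1 `O=C(N/N=C/c1cc(Br)c(O)c(Br)c1)Nc1cc2c(Nc3ccc(F)c(Cl)c3)ncnc2cc1O[C@H]1CCOC1` at 8910 nM by a gap beyond the usual scatter. Compound 3 `COc1cc2ncnc(Nc3ccc(F)c(Cl)c3)c2cc1NC(=O)N/N=C/c1cc(Br)c(O)c(Br)c1` differs from compound 2 in one place: bromo in place of hydrogen on an aromatic carbon turns 3-bromo-4-hydroxyphenyl into 3,5-dibromo-4-hydroxyphenyl, with bromo in place of hydrogen on an aromatic carbon. For the measured compounds named here, compound 1, at 8910 nM in this test, also carries that dibromo group, but no measured step isolates the change. A modest move toward stronger inhibition is therefore expected, with a 1.9-fold lower number from compound 2 to compound 3 (0.28 log units; within the scatter) as the estimated step. Compound 3 is estimated at 15000 nM with a range of 6000 nM to 35000 nM for now.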

Compound 3, half-maximal inhibitory concentration: 34600 nM
Beside the measured number, compound 3's estimate is 2.3-fold (0.36 log units) below it; the range from low to high includes it.
By their numbers in this assay, from the lowest: compound 1; then compounds 2 and 3 (each within the scatter of the next).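

In this assay, placing a second bromo ortho to the hydroxy group gives a 1.2-fold higher number from compound 2 to compound 3 (0.08 log units; within the scatter), so this added bromo separates compound 2 and compound 3 by no more than the usual scatter. With the 3,5-dibromo-4-hydroxyphenyl group held constant, methyl in place of oxolan-3-yl on the oxygen gives a 3.9-fold higher number from compound 1 to compound 3 (0.59 log units; beyond the scatter), so this second site does separate the compounds. No available evidence explains either result. Still open, going by these compounds, is how a chloro, an amine or a carboxylic acid would read at the bromo position. Also open, on these data alone, is how the bromo step would read with oxolan-3-yl on the oxygen.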